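Cytotoxicity limits across the shared core: step to compound 4

A few compounds are considered here, and "the series" means these few. Any claim that something is new, unique, unknown or untested is made for them only; others in the source may bear on it.

Compound 1 `O=C(c1ccncc1)N1N=C(c2cc3ccccc3o2)CC1c1cccc([N+](=O)[O-])c1`, compound 2 `O=C(c1ccncc1)N1N=C(c2cc3ccccc3o2)CC1c1ccccc1Cl` and compound 3 `CCn1cc(C(=O)N2N=C(c3cc4ccccc4o3)CC2c2ccccc2C(=O)O)c(=O)c2ccc(C)nc21` share one core and were run in an ADME assay on Vero cells (Chlorocebus sabaeus) for cytotoxicity, read by MTT assay, with a stated time of 72 h; on this read-out lower numbers stand for stronger inhibition and higher numbers for weaker inhibition. Compound 1 reaches only a limit, > 240000 nM. Compound 2 likewise stops at a limit, > 210000 nM. Compound 3 also returns no number but a limit, > 196000 nM. So compound 3 stands where the other two stand: all three readings are limits (the limit of > 196000 nM in this assay, at which 1 of the 3 values shown sits, (the limit of > 210000 nM in this assay, at which 1 of the 3 values shown sits), (the limit of > 240000 nM in this assay, at which 1 of the 3 values shown sits)) and none can be ordered against another. Within the data shown here, the single step between measured compounds, a step that the two limits leave unreadable from compound 1 to compound 2, cannot be read because the limit of > 240000 nM in this assay, at which 1 of the 3 values shown sits, and the limit of > 210000 nM in this assay, at which 1 of the 3 values shown sits, are both limits.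

Compound 4 `CCn1cc(C(=O)N2N=C(c3cc4ccccc4o3)CC2c2ccccc2Cl)c(=O)c2ccc(C)nc21` differs from compound 3 by chloro in place of carboxy on an aromatic carbon. No readable measured step bears on this change; the one available, a step that the two limits leave unreadable from compound 1 to compound 2, also replaces the group on that phenyl but gives no size. Compound 4 is therefore expected to sit at about 200000 nM, within 60000 nM to 500000 nM, most likely again as a limit. The step that the limit leaves unreadable from compound 3 to compound 4 is expected to show nothing beyond the scatter.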

Compound 4, half-maximal inhibitory concentration: > 178000 nM
Compound 4 gave a limit, no number; the forecaster's own chance of this, stated with the estimate: 85%; the middle value does not contradict the limit.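

The step from compound 3 to compound 4 cannot be read in this assay: both readings are limits, not numbers. The compounds shown leave open where any of the four would give an actual number in this assay, and whether chloro in place of carboxy shifts that number.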